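Piperazine nitrogen substituent on the shared core: furoyl analogue

The compounds below may be only part of what the source reports. "The series", "measured", "known", "first", "only" and "open" are said of these compounds alone.

Measured so far:
compound 1 `C=CCNC(=O)N1CCN(c2cc(N)c3cc(OC)c(OC)cc3n2)CC1`: 0.29 nM
compound 2 `COc1cc2nc(N3CCN(c4ccccc4)CC3)cc(N)c2cc1OC`: 1.72 nM

In an assay on brain for displacement of a labelled ligand from Adrenergic receptor alpha-1 (Rattus norvegicus) (on this read-out lower numbers stand for stronger inhibition and higher numbers for weaker inhibition), compound 2 gives the highest of the two numbers; its nearest neighbour is compound 1, and the step of a 5.9-fold higher number from compound 1 to compound 2 (0.77 log units; beyond the scatter) is beyond the scatter. That step replaced an allylcarbamoyl by a phenyl on the amine nitrogen in the ring.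

Compound 3 `COc1cc2nc(N3CCN(C(=O)c4ccco4)CC3)cc(N)c2cc1OC` is still to be measured in this assay. It differs from compound 2 as follows: (furan-2-yl)carbonyl in place of phenyl on an amine nitrogen in a ring. The step from compound 1 to compound 2 is the only measured one that bears on this, and it runs the opposite way: a group carrying a carbonyl left the ring nitrogen and a phenyl entered, with the number rising modestly. Compound 3 puts a carbonyl-bearing group back on that nitrogen, so a step of similar size in the lowering direction is expected, a 5.7-fold lower number from compound 2 to compound 3 (0.76 log units; beyond the scatter), because compound 1 with its allylcarbamoyl gives 0.29 nM. The estimate for compound 3 in this assay is 0.3 nM, within 0.1 nM to 1 nM.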

Compound 3, inhibition constant: 0.14 nM
Compound 3: middle estimate off by 2.1-fold (0.33 log units), on the high side, within the range that was stated.
By their numbers in this assay, from the lowest: compound 3; then compound 1; then compound 2.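

In this assay, the amine nitrogen in the ring proves sensitive to a change of group: (furan-2-yl)carbonyl in place of phenyl gives a 12-fold lower number from compound 2 to compound 3 (1.09 log units; beyond the scatter), so the phenyl group now stands above both carbonyl-bearing groups on this read-out, and none of the three compounds goes against that order. The group on the carbonyl carbon also counts, as furan-2-yl in place of allylamino gives a 2.1-fold lower number from compound 1 to compound 3 (0.32 log units; beyond the scatter), a smaller step but still beyond the scatter, which shows that the carbonyl-bearing groups on this nitrogen are not interchangeable. Nothing on hand accounts for either step.

The change from phenyl to (furan-2-yl)carbonyl alters both the ring and the presence of a carbonyl, so the compounds shown cannot divide the lowering between the two; a benzoyl group on the same nitrogen would keep the six-membered aromatic ring and add only the carbonyl. An acetyl group there would show how much of the result survives with no ring on the carbonyl carbon at all.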